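A few compounds are considered here, and "the series" means these few. Any claim that something is new, unique, unknown or untested is made for them only; others in the source may bear on it.

For the measured compounds named here, compound 2 `O=C(Nc1ccc([N+](=O)[O-])cc1)N1CCN(S(=O)(=O)c2sccc2-c2ccccc2Oc2ccc(O)c(O)c2)CC1` is the only one of the pair with a numerical result: in a functional assay on RS4-11 cells (Homo sapiens) for inhibition, read by CCK-8 assay, with a stated time of 48 h (on this read-out lower numbers stand for stronger inhibition and higher numbers for weaker inhibition), compound 2 gives 14300 nM. Compound 1 `COc1ccc(Oc2ccccc2-c2ccsc2S(=O)(=O)N2CCN(C(=S)Nc3ccc(Cl)cc3)CC2)cc1OC` reaches only a limit of the assay, > 50000 nM, and so stands at the limit of > 50000 nM in this assay, at which 1 of the 2 values shown sits. Compound 3 `O=S(=O)(c1sccc1-c1ccccc1Oc1ccc(O)c(O)c1)N1CCN(C(=S)Nc2ccc(Cl)cc2)CC1` has not yet been measured. It differs from compound 2 by a group of 10 heavy atoms (7 carbon, 1 nitrogen, 1 sulfur, 1 chlorine; one six-membered aromatic ring of carbon only) in place of a group of 12 heavy atoms (7 carbon, 2 nitrogen, 3 oxygen; one six-membered aromatic ring of carbon only), on an amine nitrogen in a ring. Going by the values given here, no measured step isolates this change, so its direction is open; compound 1 carries the same entering group yet returns only the limit. The estimate for compound 3 is 22000 nM, between 7000 nM and 50000 nM, with the expected step of a 1.5-fold higher number from compound 2 to compound 3 (0.19 log units; within the scatter) lying within the scatter.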

Compound 3, half-maximal inhibitory concentration: 7500 nM
Estimate against measurement, compound 3: 2.9-fold (0.47 log units) above; low and high end bracket the measured number.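

Replacing 3,4-dimethoxyphenyl with 3,4-dihydroxyphenyl on an oxygen on an aromatic ring gives an at least 6.6-fold lower number from compound 1 to compound 3 (0.82 log units; beyond the scatter), which shows that this position matters in these cells. The size of that step stays open-ended, since compound 1 stands at a limit: the limit of > 50000 nM in this assay, at which 1 of the 3 values shown sits.

On the amine nitrogen in a ring, the entering group and (4-nitrophenyl)carbamoyl are not told apart, with a 1.9-fold lower number from compound 2 to compound 3 (0.28 log units; within the scatter).

Still open, as far as these compounds go, is whether a single hydroxyl on that phenyl ring would suffice, and whether a simple amine or a carboxylic acid on the ring nitrogen's substituent would be tolerated.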